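A Methyl in Place of Methoxy on the Pendant Ring

The source may hold more compounds than are shown below. What is called first, only, known or untested is meant among the compounds shown, and "the series" means these compounds.

Compound 1 `CC[C@@H](Nc1c(C#N)c(-c2ccc(-c3ccccc3OC)cc2)nc2cnccc12)C(N)=O` was measured in a physicochemical assay for lipophilicity, read by HPLC, at pH 7.5 (a lower number here means a more polar compound, a higher number a more lipophilic compound), and gave 2.7. Among the three compounds measured so far it stands second highest. Compound 3 `CCOc1ccccc1-c1ccc(-c2nc3cnccc3c(NC(CC)CNS(=O)(=O)C3CC3)c2C#N)cc1` lies nearest, giving 3.6 in this assay, a number beyond the scatter above it. Compound 2 `CC[C@@H](Nc1c(C#N)c(-c2ccc(Br)cc2)nc2cnccc12)C(=O)O` lies furthest, giving 1.6 in this assay, a number beyond the scatter below it. No two of these compounds differ in a single place, so none of these gaps can be tied to one structural change.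

Compound 4 `CC[C@@H](Nc1c(C#N)c(-c2ccc(-c3cccc(C)c3)cc2)nc2cnccc12)C(N)=O` has not yet been measured. It differs from compound 1 in one place: 3-methylphenyl in place of 2-methoxyphenyl on an aromatic carbon. The group that leaves carries a hydrogen-bond acceptor; the group that enters carries none. Without a measured single-step comparison to lean on, the author expects a modest rise in this assay, beyond the usual scatter. The step is expected to be a number 0.50 log units higher from compound 1 to compound 4 (beyond the scatter). For compound 4 the estimate is 3.2, with a range from 2.8 to 3.6.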

Compound 4, distribution coefficient: 3
Compound 4: middle estimate off by 0.20 log units, on the high side; low and high end bracket the measured number.
By their numbers in this assay, from the lowest: compound 2; then compounds 1 and 4 (each within the scatter of the next); then compound 3.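

In this assay, among the compounds shown here, the step reads a number 0.30 log units higher from compound 1 to compound 4 (within the scatter) and gives the first comparison in this set that ties a difference to one structural change. At this place, para to a large group, 3-methylphenyl and 2-methoxyphenyl therefore cannot be told apart in this measurement, even though the leaving group carries a hydrogen-bond acceptor and the entering group carries none. No measured evidence bearing on the reason for this result is available.

The exchange alters both the substituent and where it sits on the pendant ring, and the compounds shown do not separate those two differences. They also leave open how the core of compound 1 would read with a pendant ring bearing an amine, a carboxylic acid or a longer chain.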